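A Purine Pair Where Amino Replaces Chloro

A few compounds are considered here, and "the series" means these few. Any claim that something is new, unique, unknown or untested is made for them only; others in the source may bear on it.

Compound 1 `ClCc1ccccc1Cn1cnc2c(Cl)nc(Cl)nc21` and compound 2 `ClCc1cccc(Cn2cnc3c(Cl)nc(Cl)nc32)c1` share the same atoms joined differently; how their two cores differ is not broken down here. In a functional assay on CAKI-1 cells (Homo sapiens) for cytotoxicity, read by sulforhodamine B assay, with a stated time of 48 h (a lower number here means a stronger inhibitor of growth, a higher number a weaker inhibitor of growth), compound 1 gives 890 nM, while compound 2 gives 5880 nM, the second highest of the three numbers recorded. Compound 3 `Nc1nc(Cl)c2ncn(Cc3ccccc3CCl)c2n1` is compound 1 after a single change, (amino in place of chloro on an aromatic carbon), and in this assay compound 3 gives 20400 nM. That change produced a 23-fold higher number from compound 1 to compound 3 (1.36 log units; beyond the scatter). Compound 2 stands nearer to compound 3 than to compound 1 in this assay, and both gaps lie beyond the scatter.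

Compound 4 `Nc1nc(Cl)c2ncn(Cc3cccc(CCl)c3)c2n1` has not yet been measured. It differs from compound 2 by amino in place of chloro on an aromatic carbon, and the place of the change is described in exactly the same words as for the change from compound 1 to compound 3, so this is the same change made on the core of compound 2. Within the data shown here, with only one earlier example of it, the expectation rests on that single step: the large rise seen in a 23-fold higher number from compound 1 to compound 3 (1.36 log units; beyond the scatter). Carried over to compound 2, the step to compound 4 in this assay is expected to be a 17-fold higher number from compound 2 to compound 4 (1.23 log units; beyond the scatter). Because compound 2 starts at 5880 nM, the number for compound 4 is therefore expected to come out near 100000 nM, within a range from 30000 nM to 300000 nM. At such a height the assay may report only a limit rather than a number.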

Compound 4, concentration for total growth inhibition: 1510 nM
Estimate against measurement, compound 4: 66-fold (1.82 log units) above; the measured number lies below the stated range.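

Amino in place of chloro on an aromatic carbon gave a 3.9-fold lower number from compound 2 to compound 4 (0.59 log units; beyond the scatter) in this assay, a modest step that runs in the opposite direction to the large rise seen on the other core. Set side by side, the two steps show that in this series the same single change cannot be carried from one core to the other, neither in size nor in direction, and that the result depends on the core that receives it: the same change on two cores in this assay, a 23-fold higher number (1.36 log units; beyond the scatter) from compound 1 to compound 3 and a 3.9-fold lower number (0.59 log units; beyond the scatter) from compound 2 to compound 4, 89-fold (1.95 log units) apart, beyond the scatter of two such steps

What this does not show is why the two steps part, since two pairs of compounds identify no feature of the cores as responsible, and it does not tell which of the two steps, if either, would be the more typical on a further core.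

The compounds shown leave open whether a methoxy group or a dimethylamino group on the same aromatic carbon would follow the step seen on one core, the step seen on the other, or neither. They also leave open whether the split between the two steps would persist if a hydroxymethyl group stood in place of the chloromethyl group on either core.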